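Five-position swap on the uridine monophosphate core

This account rests on a few compounds, and the source may have more. Where it says the series, first, only, none or still open, it means among the compounds named here.

Compound 1 `O=c1[nH]c(=O)n([C@H]2C[C@H](O)[C@@H](COP(=O)(O)O)O2)cc1Br` is assessed in a functional assay (Raji cells) for antiproliferative activity, with Homo sapiens as the target (on this read-out lower numbers stand for stronger inhibition and higher numbers for weaker inhibition), and gives 26 ug/mL. Of the two compounds with a single number in this assay, compound 1 carries the highest one. Its nearest neighbour is compound 2 `O=c1[nH]c(=O)n([C@H]2C[C@@H]3O[PH](O)(O)OC[C@H]3O2)cc1F`, which in this assay gives 0.164 ug/mL; the gap between compound 2 and compound 1 lies well beyond the scatter of repeated measurements. Compound 3 `O=c1[nH]c(=O)n([C@H]2C[C@@H]3OP(=O)(OCc4ccccc4)OC[C@H]3O2)cc1I` gives > 100 ug/mL; 69 ug/mL (2 entries) in this assay. The repeat entries, (the several entries of compound 3 in this assay, > 100 ug/mL; 69 ug/mL (2 entries)), agree that compound 3 sits at the weak end of the set.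

Compound 4 `O=c1[nH]c(=O)n([C@H]2C[C@H](O)[C@@H](COP(=O)(O)O)O2)cc1C(F)(F)F` has not been measured. Against compound 1 the change is trifluoromethyl in place of bromo on an aromatic carbon. Among the measured compounds shown here, no step between measured compounds separates these two substituents, so the expectation rests on compound 1 alone. A modest step toward stronger inhibition is expected, one that may still fall within the scatter of this assay: for compound 4 the estimate is 8 ug/mL, with a range from 1.5 ug/mL to 40 ug/mL. The expected step is a 3.3-fold lower number from compound 1 to compound 4 (0.51 log units; beyond the scatter).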

Compound 4, concentration for 50% inhibition: 0.169 ug/mL
Compound 4: the middle estimate sits 47-fold (1.68 log units) above what was measured; measured number below the stated range.
By their numbers in this assay, from the lowest: compounds 2 and 4 (each within the scatter of the next); then compound 1.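

In this assay, among the compounds shown here, trifluoromethyl in place of bromo on an aromatic carbon gives a 150-fold lower number from compound 1 to compound 4 (2.19 log units; beyond the scatter), the only step in the set between compounds that differ in one place. The earlier compounds shown here differ from one another in more than one place, so they could not isolate this position; this step shows that a swap here alone, with the rest of the core of compound 1 unchanged, can shift this read-out by a large margin. No measured property of bromo or trifluoromethyl is available, and the repeat entries of compound 3 have no bearing on this swap, so the data offer no account of the size of the step.

From the compounds shown here alone, a single step on one core does not define how this position responds in general: whether a nitrile, a methyl or an amine here would stay close to compound 4 or to compound 1 remains open. Also open, going by these compounds, is whether trifluoromethyl in place of the halogen would give a step of similar size on the core of compound 2 or of compound 3.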